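A Second Nitro Group on an Already Weak Inhibitor

The source may report more compounds than this note shows. Statements on the series, on what has been measured and on what is new or still open speak of the compounds shown alone.

Compound 2 `O=C(NN=C1CC(c2ccccc2)NC(c2ccccc2)C1)c1ccc([N+](=O)[O-])cc1` gives 170000 nM in a functional assay, read by spectrophotometry (a higher number here means a weaker inhibitor, a lower number a stronger inhibitor), the highest of the two numbers measured; its nearest neighbour is compound 1 `O=C(NN=C1CC(c2ccccc2)NC(c2ccccc2)C1)c1ccc(C(F)(F)F)cc1` with 153000 nM, and a 1.1-fold higher number from compound 1 to compound 2 (0.05 log units; within the scatter) lies within the scatter. Compound 3 `O=C(NN=C1CC(c2ccccc2)NC(c2ccccc2)C1)c1ccc([N+](=O)[O-])cc1[N+](=O)[O-]` differs from compound 2 by nitro in place of hydrogen on an aromatic carbon. For the measured compounds named here, the only measured step, from compound 1 to compound 2, exchanged one group for nitro on that ring and stayed within the scatter, so it bears on this change only loosely; no step beyond the scatter is expected in this assay. Compound 3 is therefore estimated at 170000 nM, between 60000 nM and 500000 nM, an expected step of no change at the digits printed from compound 2 to compound 3 (within the scatter).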

Compound 3, half-maximal inhibitory concentration: 19300 nM
Beside the measured number, compound 3's estimate is 8.8-fold (0.94 log units) above it; measured number outside the range, below it.
By their numbers in this assay, from the lowest: compound 3; then compounds 1 and 2 (each within the scatter of the next).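

In this assay, for the compounds shown here, the added nitro group gives an 8.8-fold lower number from compound 2 to compound 3 (0.94 log units; beyond the scatter) and so produces the first step in this small set to lie beyond the scatter. The position ortho to a large group, which carries hydrogen in compounds 1 and 2, can therefore shift this read-out, whereas the earlier exchange of trifluoromethyl for nitro did not. No available evidence accounts for this gain in strength.

As far as these compounds go, whether the gain is specific to nitro remains open: an amine, a carboxylic acid or a fluorine at this position would test that. It is also unknown whether the gain depends on the nitro group already present in compound 2.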